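From 4-methoxybenzyl to 4-fluorobenzyl: an expected outcome

A few compounds are considered here, and "the series" means these few. Any claim that something is new, unique, unknown or untested is made for them only; others in the source may bear on it.

- compound 1 `COc1ccc(Cc2nnc(NC(=O)/C(C#N)=C/c3ccccc3OS(=O)(=O)c3ccc(OC)cc3)s2)cc1` gives 78%
- compound 2 `COc1ccc(Cc2nnc(NC(=O)/C(C#N)=C/c3ccccc3OS(=O)(=O)c3ccccc3[N+](=O)[O-])s2)cc1` gives 68%

Among the measured compounds shown here, both values come from a functional assay on RS4-11 cells (Homo sapiens) for inhibition, read by CCK-8 assay, with a stated time of 48 h, tested at 20 uM (on this read-out higher numbers stand for more inhibition of growth at the one concentration tested and lower numbers for less inhibition of growth), and compound 1 sits within the scatter of compound 2, its only neighbour here. Compound 3 `COc1ccc(S(=O)(=O)Oc2ccccc2/C=C(\C#N)C(=O)Nc2nnc(Cc3ccc(F)cc3)s2)cc1` has not yet been measured. Its difference from compound 1 is fluoro in place of methoxy on an aromatic carbon and lies in a single place: fluoro in place of methoxy on an aromatic carbon, turning 4-methoxybenzyl into 4-fluorobenzyl. For the measured compounds named here, the only measured step is a number 10 percentage points lower from compound 1 to compound 2 (within the scatter) and it concerns a different place, with 2-nitrophenyl in place of 4-methoxyphenyl on a sulfonyl sulfur. It therefore gives no direct guide to this change. Going by the values given here, with no measured step at this place, no shift beyond the scatter is expected in either direction. The estimate is an expected step of a number 4 percentage points lower from compound 1 to compound 3 (within the scatter) on this scale. For compound 3 the estimated value is 74% within an expected range of 58% to 88% on this read-out.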

Compound 3, percent growth inhibition at one concentration: 76%
Estimate against measurement, compound 3: 2 percentage points below; measured number inside the range.
By their numbers in this assay, from the lowest: compounds 2, 3 and 1 (each within the scatter of the next).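

Turning 4-methoxybenzyl into 4-fluorobenzyl gives a number 2 percentage points lower from compound 1 to compound 3 (within the scatter) in this assay, and this is the only measured step at this position. At this single concentration, the read-out does not separate methoxy from fluoro on this aromatic carbon, so the methoxy is not required for the level of growth inhibition seen with compound 1. Nothing available explains why the two groups read alike.

The compounds shown leave open whether this position accepts very different groups, such as an amine, a carboxylic acid or a longer chain like butoxy. On these data alone, it also remains open whether 4-fluorobenzyl and 4-methoxybenzyl would still read alike at lower concentrations, or alongside the 2-nitrophenyl group on the sulfonyl sulfur.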